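A few compounds are considered here, and "the series" means these few. Any claim that something is new, unique, unknown or untested is made for them only; others in the source may bear on it.

For the measured compounds named here, the three compounds measured so far share one core and differ only in the group attached to it. Compound 1, `O=C(CCCCCCc1ccccc1)c1ncc(-c2ccccc2F)o1`, carries a 2-fluorophenyl group and in an assay (Rattus norvegicus) for inhibition of Fatty-acid amide hydrolase 1 (Homo sapiens) (a higher number here means a weaker inhibitor, a lower number a stronger inhibitor), compound 1 gives 110 nM. Compound 2, `O=C(CCCCCCc1ccccc1)c1ncc(-c2cccc(O)c2)o1`, carries a 3-hydroxyphenyl group instead, and compound 2 gives 50 nM. Compound 3, `O=C(CCCCCCc1ccccc1)c1ncc(-c2cncnc2)o1`, carries a pyrimidin-5-yl group, and compound 3 gives 22 nM, the lowest of the three numbers. Each swap of one aromatic ring for another moved the number modestly: a 2.2-fold lower number from compound 1 to compound 2 (0.34 log units; beyond the scatter), a 5.0-fold lower number from compound 1 to compound 3 (0.70 log units; beyond the scatter), and a 2.3-fold lower number from compound 2 to compound 3 (0.36 log units; beyond the scatter).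

Compound 4, `CC(=O)c1cnc(C(=O)CCCCCCc2ccccc2)o1`, takes a different kind of step: acetyl in place of pyrimidin-5-yl on an aromatic carbon. The aromatic ring is not swapped for another ring but replaced by a small open group, so none of the three measured steps covers this change directly. Going by the values given here, they show only that the group at this place shifts the number by modest amounts. Among the compounds with values here, with no closer precedent, compound 4 is estimated to give 45 nM, within a range from 8 nM to 250 nM, which corresponds to an expected step of a 2.0-fold higher number from compound 3 to compound 4 (0.31 log units; beyond the scatter).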

Compound 4, inhibition constant: 2 nM
Estimate against measurement, compound 4: 23-fold (1.35 log units) above; measured number outside the range, below it.
By their numbers in this assay, from the lowest: compound 4; then compound 3; then compound 2; then compound 1.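

The earlier swaps of one aromatic ring for another moved the number only modestly, and they gave no sign of how much more this place could change it in this assay. This place, on an aromatic carbon next to the ring oxygen, turns out to respond far more strongly when the ring gives way to acetyl, with a large step against each ring compound: an 11-fold lower number from compound 3 to compound 4 (1.04 log units; beyond the scatter), a 25-fold lower number from compound 2 to compound 4 (1.40 log units; beyond the scatter), and a 55-fold lower number from compound 1 to compound 4 (1.74 log units; beyond the scatter). So an aromatic ring at this place is not needed for a low number, although nothing measured here explains why the small open group does so much better than the three rings.

The four compounds leave open whether this low number belongs to acetyl alone or would also appear with other small groups at this place, such as a methyl ester, a carboxylic acid, a nitrile or a simple methyl group. They also leave open whether the same gain would hold if the long chain ending in a phenyl ring, which is identical in all four compounds, were shorter or longer.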